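The source may report more compounds than this note shows. Statements on the series, on what has been measured and on what is new or still open speak of the compounds shown alone.

Measured so far in a functional assay on isolated protein for agonist activity at Glucose-dependent insulinotropic receptor (Mus musculus), read by cAMP accumulation; on this read-out higher numbers stand for an effect only at larger amounts of compound and lower numbers for an effect already at smaller amounts:
- compound 1 `CC(C)c1noc(N2CCC([C@H]3C[C@H]3COCc3ccc(S(C)(=O)=O)cc3F)CC2)n1` gives 9.9 nM
- compound 2 `CC(C)c1noc(N2CCC([C@H]3C[C@H]3COCc3ccc(-n4cnnn4)cc3F)CC2)n1` gives 4.8 nM

For the measured compounds named here, compound 1 has the higher of the two numbers in this assay; the single measured step, a 2.1-fold lower number from compound 1 to compound 2 (0.31 log units; beyond the scatter), concerns the substituent on the aromatic carbon of the fluorinated ring only.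

Compound 3 `COc1cnc(N2CCC([C@H]3C[C@H]3COCc3ccc(S(C)(=O)=O)cc3F)CC2)nc1` differs from compound 1 at a different site: 5-methoxypyrimidin-2-yl in place of 3-isopropyl-1,2,4-oxadiazol-5-yl on an amine nitrogen in a ring. Going by the values given here, no measured step touches the group on the amine nitrogen in the ring, so the change from compound 1 to compound 2 gives no direct guidance for it; it only shows that this core tolerates modest variation elsewhere without losing activity.

Without a comparable precedent, the expected step of a 1.5-fold higher number from compound 1 to compound 3 (0.18 log units; within the scatter) is taken as small, with the number for compound 3 estimated at 15 nM, in a range from 4 nM to 60 nM, which reflects the uncertainty of an untested exchange at this position.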

Compound 3, half-maximal effective concentration: 1.4 nM
For compound 3 the middle estimate is 11-fold (1.03 log units) above the measured one; measured number below the stated range.
By their numbers in this assay, from the lowest: compound 3; then compound 2; then compound 1.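

In this assay, the group on the amine nitrogen in a ring proves to be a position where the number can move: a 7.1-fold lower number from compound 1 to compound 3 (0.85 log units; beyond the scatter). The two groups match in their counts of heavy atoms, hydrogen-bond donors and hydrogen-bond acceptors, yet differ in the ring, with a six-membered aromatic ring with 2 hetero atoms replacing a five-membered aromatic ring with 3 hetero atoms, so equal counts alone do not fix the number at this position. Nothing available here accounts for the step.

The compounds shown leave open whether the step follows the ring itself or the methoxy group on it, a question that an unsubstituted pyrimidin-2-yl or a 5-chloropyrimidin-2-yl group would address. Also open, going by these compounds, is whether 5-methoxypyrimidin-2-yl and 1H-tetrazol-1-yl would add up within a single compound.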